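The source may hold more compounds than are shown below. What is called first, only, known or untested is meant among the compounds shown, and "the series" means these compounds.

Measured so far:
compound 1, `O=C1/C(=C/c2cccnc2)CN(S(=O)(=O)c2ccc([N+](=O)[O-])cc2)C/C1=C\c1ccccc1F`: > 20000 nM
compound 2, `O=C1/C(=C/c2cccnc2)CN(S(=O)(=O)c2ccc([N+](=O)[O-])cc2)C/C1=C\c1ccccc1C(F)(F)F`: 15700 nM
compound 3, `O=C1/C(=C/c2cccnc2)CN(S(=O)(=O)c2ccc(C(F)(F)F)cc2)C/C1=C\c1ccccc1C(F)(F)F`: 14300 nM

All three were tested in an ADME assay on L02 cells (Homo sapiens) for cytotoxicity, read by MTT assay, with a stated time of 24 h; on this read-out lower numbers stand for stronger inhibition and higher numbers for weaker inhibition. The value of compound 1 is a limit of the assay rather than a number, (the limit of > 20000 nM in this assay, at which 1 of the 3 values shown sits). Compound 2 and compound 3 differ in their cores by trifluoromethyl in place of nitro on an aromatic carbon, which gave a 1.1-fold lower number from compound 2 to compound 3 (0.04 log units; within the scatter). From compound 2 to compound 1 the change is fluoro in place of trifluoromethyl on an aromatic carbon, and it gave an at least 1.2-fold higher number from compound 2 to compound 1 (0.10 log units; that floor lies within the scatter).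

Compound 4, `O=C1/C(=C/c2cccnc2)CN(S(=O)(=O)c2ccc(F)cc2)C/C1=C\c1ccccc1C(F)(F)F`, has not been measured. It differs from compound 3 by fluoro in place of trifluoromethyl on an aromatic carbon. This is the same kind of change as from compound 2 to compound 1, but not the same: there the place was ortho to a large group, here it is para to a large group, on a different ring of the core. For compound 4 a step of a 1.2-fold higher number from compound 3 to compound 4 (0.08 log units; within the scatter) is expected, and this rests on the earlier step of an at least 1.2-fold higher number from compound 2 to compound 1 (0.10 log units; that floor lies within the scatter) having stayed near the value of compound 2. Compound 4 is therefore estimated at 17000 nM in this assay, with a likely range from 9000 nM to 32000 nM.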

Compound 4, half-maximal inhibitory concentration: 16100 nM
For compound 4 the middle estimate is 1.1-fold (0.02 log units) above the measured one; low and high end bracket the measured number.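

In this assay the new value gives a 1.1-fold higher number from compound 3 to compound 4 (0.05 log units; within the scatter), and fluoro in place of nitro gives a 1.0-fold higher number from compound 2 to compound 4 (0.01 log units; within the scatter). Set beside the same change on the other core, the step from trifluoromethyl to fluoro can be compared only in part: the same change on two cores in this assay, an at least 1.2-fold higher number (0.10 log units; that floor lies within the scatter) from compound 2 to compound 1 and a 1.1-fold higher number (0.05 log units; within the scatter) from compound 3 to compound 4; the limit leaves it open whether they differ. On these data alone, the new pair therefore gives a real number for this change on one core and shows no step beyond the scatter there, but the value of compound 1 is a limit of the assay, so how far the step on its core truly runs stays unknown, and two pairs cannot establish a rule for the series.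

The compounds shown leave open how the number would respond to quite different groups on the ring that carries fluoro, trifluoromethyl or nitro, such as an amine or a carboxylic acid. They also leave open whether any such group would give a step beyond the scatter in this assay.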